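Acid Chain in Place of an Aryl Ester on the Ring

The compounds below may be only part of what the source reports. "The series", "measured", "known", "first", "only" and "open" are said of these compounds alone.

Compound 2 `CCCCCCCCc1ccc(OCC(=O)Cn2nnc(-c3ccc(C(=O)OC)cc3)n2)cc1` is one of three compounds that share a core and differ only in the group on the five-membered aromatic ring with 4 nitrogen. In an assay on microsomes from brain for inhibition of Fatty-acid amide hydrolase 1 (Rattus norvegicus), read by fluorescence and HPLC, with a stated time of 60 min (a higher number here means a weaker inhibitor, a lower number a stronger inhibitor), compound 2 gives 29 nM. Compound 1 `CCCCCCCCc1ccc(OCC(=O)Cn2nnc(C)n2)cc1` gives 27 nM in this assay, and compound 3 `CCCCCCCCc1ccc(OCC(=O)Cn2nnc(-c3cccc(C(=O)OC)c3)n2)cc1` gives 34 nM. Compound 2 thus holds the second highest of the three numbers, nearest to compound 1 and furthest from compound 3, with every gap inside the scatter: a 1.1-fold higher number from compound 1 to compound 2 (0.03 log units; within the scatter), a 1.3-fold higher number from compound 1 to compound 3 (0.10 log units; within the scatter) and a 1.2-fold higher number from compound 2 to compound 3 (0.07 log units; within the scatter).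

Compound 4 `CCCCCCCCc1ccc(OCC(=O)Cn2nnc(CCC(=O)O)n2)cc1` has not yet been measured. It differs from compound 2 by 2-carboxyethyl in place of 4-(methoxycarbonyl)phenyl on an aromatic carbon. All three measured steps bear on this change, since each swaps the group at the same place, and none left the scatter across methyl, 4-(methoxycarbonyl)phenyl and 3-(methoxycarbonyl)phenyl. Going by the values given here, no measured compound carries a 2-carboxyethyl group, so that part of the change has no precedent here, and the range must stay wide. Compound 4 is therefore expected to give 45 nM, between 12 nM and 180 nM. That expectation amounts to a step of a 1.6-fold higher number from compound 2 to compound 4 (0.19 log units; within the scatter), with no firm direction beyond the scatter.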

Compound 4, half-maximal inhibitory concentration: 30 nM
Compound 4: middle estimate off by 1.5-fold (0.18 log units), on the high side; measured number inside the range.
By their numbers in this assay, from the lowest: compounds 1, 2, 4 and 3 (each within the scatter of the next).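

Until now, this place on the five-membered aromatic ring with 4 nitrogen had held only methyl and two groups with a methyl ester on a benzene ring, none with a hydrogen-bond donor. The 2-carboxyethyl group has no ring and ends in a carboxylic acid with one hydrogen-bond donor, yet in this assay compound 4 stays within the scatter of all three earlier compounds (a 1.0-fold higher number from compound 2 to compound 4 (0.01 log units; within the scatter); a 1.1-fold lower number from compound 3 to compound 4 (0.05 log units; within the scatter); a 1.1-fold higher number from compound 1 to compound 4 (0.05 log units; within the scatter)). Nothing at hand explains why the number holds across such different groups.

Going by these compounds, whether the carboxylic acid itself matters stays open, since the methyl ester of the 2-carboxyethyl chain would compare the two directly. A primary amine on the same chain, or a longer chain ending in a carboxylic acid, would show how far this freedom at the position extends.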